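The source may report more compounds than this note shows. Statements on the series, on what has been measured and on what is new or still open speak of the compounds shown alone.

In a functional assay on MCF7 cells (Homo sapiens) for antiproliferative activity, read by MTT assay, with a stated time of 48 h (a lower number here means a stronger inhibitor, a higher number a weaker inhibitor), two compounds sharing one core have been measured so far, compound 1 `CCn1c(C(=O)NCC#N)ccc1C(CC)(CC)c1ccc(OCCC(O)(CC)CC)c(C)c1` and compound 2 `CCC(C)C(NC(=O)c1ccc(C(CC)(CC)c2ccc(OCCC(O)(CC)CC)c(C)c2)n1CC)C(=O)OC`. Compound 1 gives > 50000 nM, which is a limit of the assay and not a number. Compound 2 gives > 50000 nM, which is also a limit. Compound 2 therefore has no numerical standing, and the whole record is the limit of > 50000 nM in this assay, at which 2 of the 2 values shown sit. Among the compounds with values here, the one measured step is a step that the two limits leave unreadable from compound 1 to compound 2, so no size can be carried forward from it.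

Compound 3 `CCn1c(C(=O)NC(CC(=O)O)C(=O)OC)ccc1C(CC)(CC)c1ccc(OCCC(O)(CC)CC)c(C)c1` changes compound 2 at a single place: carboxymethyl in place of sec-butyl on a saturated chain carbon bound to an amide-type nitrogen and a carbonyl carbon. This places carboxymethyl in place of sec-butyl on a saturated chain carbon bound to an amide-type nitrogen and a carbonyl carbon. Within the data shown here, nothing measured so far tests this change, so this assay offers no direction for it and no reason to expect a shift beyond the scatter. The likeliest outcome is that compound 3 also reports only a limit. The expected size is a number no higher from compound 2 to compound 3 (the limit leaves the size open). For compound 3 the estimated value is 50000 nM, with an expected range from 20000 nM to 100000 nM.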

Compound 3, half-maximal inhibitory concentration: 10200 nM
Compound 3: the middle estimate sits 4.9-fold (0.69 log units) above what was measured, outside the stated range (below it).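

In this assay, within the data shown here, compound 3 is the first compound in this set to give a number and not a limit, which shows that the saturated chain carbon bound to an amide-type nitrogen and a carbonyl carbon is a place where a single change can bring a measurable read-out. Carboxymethyl in place of sec-butyl gives an at least 4.9-fold lower number from compound 2 to compound 3 (0.69 log units; beyond the scatter), and the whole group on the amide-type nitrogen, compared with the one in compound 1, gives an at least 4.9-fold lower number from compound 1 to compound 3 (0.69 log units; beyond the scatter); both sizes are lower bounds, since each starts from a limit and not from a number. The step from compound 1 to compound 2 cannot be read, so compound 3 alone carries the new information, and the rest of the record remains at a limit: the limit of > 50000 nM in this assay, at which 2 of the 3 values shown sit.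

On these data alone, the true size of the step remains open, and a single pair cannot tell whether the gain belongs to carboxymethyl in particular or would also come with another group at this place. Whether a longer chain ending in a carboxylic acid, a primary amide or an aminomethyl group at the same carbon would give a lower or a higher number than compound 3 is also unanswered by the compounds shown.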